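Cytotoxicity Limits Across Three Measured Compounds and One Unmeasured

A few compounds are considered here, and "the series" means these few. Any claim that something is new, unique, unknown or untested is made for them only; others in the source may bear on it.

Compound 1 `CCOC(=O)c1c(-c2cccc(-c3ccccc3)c2)[nH]c2cc(OC)ccc2c1=O`: > 21500 nM
Compound 2 `CCOC(=O)c1c(-c2cccc(OC)c2)[nH]c2cc(OC)ccc2c1=O`: > 21500 nM
Compound 3 `CCOC(=O)c1c(-c2cccc(-c3ccccc3)c2)[nH]c2cc(Cl)c(Cl)cc2c1=O`: > 21500 nM

All three were tested in an ADME assay on HepG2 cells (Homo sapiens) for cytotoxicity, read by luminescence, with a stated time of 72 h; on this read-out higher numbers stand for an effect only at larger amounts of compound and lower numbers for an effect already at smaller amounts. In this assay compound 1 gives > 21500 nM, which is a limit of the assay and not a number. Compound 2 gives > 21500 nM, also a limit. Compound 3 gives > 21500 nM, again a limit. The change from compound 1 to compound 2 is methoxy in place of phenyl on an aromatic carbon. The step it made, a step that the two limits leave unreadable from compound 1 to compound 2, has no readable size because the limit of > 21500 nM in this assay, at which 3 of the 3 values shown sit, is where both values sit. Compound 3 and compound 1 have different cores; the difference between the two cores is not broken down here.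

Compound 4 `CCOC(=O)c1c(-c2cccc(OC)c2)[nH]c2cc(Cl)c(Cl)cc2c1=O` has not yet been measured. It differs from compound 3 by methoxy in place of phenyl on an aromatic carbon, the same change as that from compound 1 to compound 2. The step from compound 3 to compound 4 is expected to be about a step that the limit leaves unreadable from compound 3 to compound 4, resting on the unreadable step between compound 1 and compound 2 and on the shared limit. Compound 4 is therefore expected to give roughly 30000 nM, most likely reported again only as a limit, between 15000 nM and 100000 nM.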

Compound 4, half-maximal effective concentration: > 21500 nM
Compound 4: a limit, no number; the forecaster's own chance of this, stated with the estimate: 85%; the middle value lies beyond the limit too.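

No step can be read between compound 3 and compound 4, because both give only a limit of the assay and not a number: the limit of > 21500 nM in this assay, at which 4 of the 4 values shown sit.

The compounds shown leave open at what concentration, if any, each would affect these cells in this assay and whether methoxy in place of phenyl changes that concentration at all.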